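A few compounds are considered here, and "the series" means these few. Any claim that something is new, unique, unknown or untested is made for them only; others in the source may bear on it.

Compound 1 `COc1n[nH]c2ncc(-c3cn(-c4c(F)ccc(NS(=O)(=O)c5cccc(Cl)c5)c4F)nn3)cc12`: 1.9 nM
Compound 2 `COc1n[nH]c2ncc(-c3cn(-c4c(F)ccc(NS(=O)(=O)c5ccccc5)c4F)nn3)cc12`: 3.8 nM
Compound 3 `COc1n[nH]c2ncc(-c3cn(-c4c(F)ccc(NS(=O)(=O)c5cccc(Br)c5)c4F)nn3)cc12`: 2.1 nM

All three were measured in an assay on Sf9 cells for inhibition of mitogen-activated protein kinase kinase kinase 20 (Homo sapiens), read by ADP-Glo, with a stated time of 30 min; a higher number here means a weaker inhibitor, a lower number a stronger inhibitor. Compound 3 holds the second highest of the three numbers. Its nearest neighbour is compound 1: a 1.1-fold higher number from compound 1 to compound 3 (0.04 log units; within the scatter). Its furthest is compound 2: a 1.8-fold lower number from compound 2 to compound 3 (0.26 log units; within the scatter). Since each of these steps lies within the scatter, no order among the three is claimed.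

Compound 4 `COc1cccc(S(=O)(=O)Nc2ccc(F)c(-n3cc(-c4cnc5[nH]nc(OC)c5c4)nn3)c2F)c1` has not yet been measured. It differs from compound 3 by methoxy in place of bromo on an aromatic carbon. Going by the values given here, no measured step puts a methoxy at this place; the measured steps exchange only a halogen for hydrogen or for another halogen there: a 2.0-fold higher number from compound 1 to compound 2 (0.30 log units; within the scatter), a 1.8-fold lower number from compound 2 to compound 3 (0.26 log units; within the scatter) and a 1.1-fold higher number from compound 1 to compound 3 (0.04 log units; within the scatter). Every one of them stays within the scatter, so the exchanges tested at this place left this assay essentially unchanged. A methoxy group is a different kind of change, and the data give no direct guide, so the expectation is a step of no more than the scatter, in either direction. The estimate for compound 4 in this assay is 2.5 nM, with a range from 1.2 nM to 6 nM. That estimate means an expected step of a 1.2-fold higher number from compound 3 to compound 4 (0.08 log units; within the scatter).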

Compound 4, half-maximal inhibitory concentration: 2.3 nM
Compound 4: the middle estimate sits 1.1-fold (0.04 log units) above what was measured; the range from low to high includes it.
By their numbers in this assay, from the lowest: compounds 1, 3, 4 and 2 (each within the scatter of the next).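

In this assay, going by these compounds alone, the change from bromo to methoxy is the first at this place to bring in a group that is not a halogen or hydrogen, and one that counts a hydrogen-bond acceptor, yet the number barely shifts (a 1.1-fold higher number from compound 3 to compound 4 (0.04 log units; within the scatter)). The same holds against chloro (a 1.2-fold higher number from compound 1 to compound 4 (0.08 log units; within the scatter)) and against hydrogen (a 1.7-fold lower number from compound 2 to compound 4 (0.22 log units; within the scatter)), so this aromatic carbon, meta to a large group, has now carried four different substituents with every step among them within the scatter and no order among them. Nothing available explains why these exchanges leave the number so little changed.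

On these data alone, whether an amine, a carboxylic acid or a longer chain such as butoxy would move the number beyond the scatter stays open. So does whether the other carbons of this ring tolerate such exchanges equally.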